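Swapping Methoxy for Chloro in a Urea Series

The source may hold more compounds than are shown below. What is called first, only, known or untested is meant among the compounds shown, and "the series" means these compounds.

Three ureas sharing one core have been measured in an ADME assay on the whole organism with Oryza sativa as the target, tested at 0.1 uM; on this read-out higher numbers stand for a weaker effect at the one concentration tested and lower numbers for a stronger effect. Compound 1, `CC(C)c1ccccc1NC(=O)N[C@@H](C)c1ccccc1`, gives 99%. Compound 2, `COc1ccccc1NC(=O)N[C@H](C)c1ccccc1`, gives 100%. Compound 3, `COc1ccccc1NC(=O)N[C@@H](C)c1ccccc1`, gives 98%, which is the lowest of the three numbers, though the step of a number 1 percentage points lower from compound 1 to compound 3 (within the scatter) and the step of a number 2 percentage points lower from compound 2 to compound 3 (within the scatter) both stay within the usual scatter, so the three compounds cannot be told apart on these readings. The second of those steps is a pure change of configuration, as shown by the fact that compounds 2 and 3 differ only in the configuration as drawn.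

The next compound, compound 4, `C[C@H](NC(=O)Nc1ccccc1Cl)c1ccccc1`, has not yet been measured. It differs from compound 3 in one place: chloro in place of methoxy on an aromatic carbon. Among the measured compounds shown here, of the measured steps, the one from compound 1 to compound 3 is the closest relative, since it also exchanged one group on an aromatic carbon of the same ring, and it produced a change within the scatter. The stereochemical step likewise produced a change within the scatter. For the measured compounds named here, with no measured step showing movement beyond the scatter, no shift beyond the scatter is expected for compound 4 either, so the expected step is a number 1 percentage points lower from compound 3 to compound 4 (within the scatter). Compound 4 is therefore estimated at 97%, within a range from 85% to 100%.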

Compound 4, a percentage reported as activity, at one concentration (the size of the read-out at that concentration, not a potency): 99%
Beside the measured number, compound 4's estimate is 2 percentage points below it; measured number inside the range.
By their numbers in this assay, from the lowest: compounds 3, 1, 4 and 2 (each within the scatter of the next).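

At this position, on an aromatic carbon ortho to a large group, chloro now joins isopropyl and methoxy as a third group read in this assay, and it gives a number 1 percentage points higher from compound 3 to compound 4 (within the scatter) and no change at the digits printed from compound 1 to compound 4 (within the scatter). The earlier compounds had shown only that methoxy and isopropyl could not be told apart; these steps add a smaller group, a single chlorine atom, and the readings still cannot be told apart, even though the change from methoxy also removes the group's one hydrogen-bond acceptor. So across these three groups, which differ in their atoms and in their size, this position has shown no change beyond the scatter, and nothing available explains these readings.

On these data alone, what remains open is whether any group at this position can move the number beyond the scatter at the one concentration tested, for instance an amine or a carboxylic acid, both of which differ from the three groups read so far in the atoms they carry. As far as these compounds go, it is also open whether the drawn configuration of the chain carbon matters with chloro in place, since only the methoxy pair speaks to that.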